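Swapping Amino for Hydroxy on the Shared Core

This account rests on a few compounds, and the source may have more. Where it says the series, first, only, none or still open, it means among the compounds named here.

Measured in a functional assay on K562 cells (Homo sapiens) for cytotoxicity; a higher number here means a weaker inhibitor, a lower number a stronger inhibitor:
- Compound 1 `CCC(CO)Nc1nc(NCc2ccccc2)c2nc(Br)n(C(C)C)c2n1`: 27000 nM
- Compound 2 `CCC(CO)Nc1nc(NCc2ccccc2)c2nc(N)n(C(C)C)c2n1`: 80000 nM

Compound 2 holds the higher of the two numbers, at 80000 nM. Compound 3 `CCC(CO)Nc1nc(NCc2ccccc2)c2nc(O)n(C(C)C)c2n1` differs from it in one group: hydroxy in place of amino on an aromatic carbon. Among the compounds with values here, only one measured step bears on this change, a modest one at an aromatic carbon, a 3.0-fold higher number from compound 1 to compound 2 (0.47 log units; beyond the scatter). From the compounds shown here alone, with so little evidence, no step beyond the scatter is expected in this assay, and the direction stays open. The expected step is a 1.1-fold lower number from compound 2 to compound 3 (0.06 log units; within the scatter). Compound 3 is estimated at 70000 nM, within an expected range of 25000 nM to 170000 nM.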

Compound 3, half-maximal inhibitory concentration: 74000 nM
Estimate against measurement, compound 3: 1.1-fold (0.02 log units) below, and the stated range covers the measured number.
By their numbers in this assay, from the lowest: compound 1; then compounds 3 and 2 (each within the scatter of the next).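

At this aromatic carbon between two ring nitrogen atoms, hydroxy and amino cannot be told apart in this assay: the change gives a 1.1-fold lower number from compound 2 to compound 3 (0.03 log units; within the scatter). Replacing bromo with hydroxy gives a 2.7-fold higher number from compound 1 to compound 3 (0.44 log units; beyond the scatter), so among these three compounds, bromo holds the lowest number, and both replacements stand beyond the scatter from it. Nothing available explains this result.

From the compounds shown here alone, whether chloro, methyl or a carboxylic acid at this carbon would match compound 1 or pass it remains open. So does whether the same order would hold with a longer chain in place of the isopropyl group.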